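Nitrogen substituent change in a pyrrolidine thromboxane antagonist series

The source may report more compounds than this note shows. Statements on the series, on what has been measured and on what is new or still open speak of the compounds shown alone.

Measured so far:
compound 1 `O=C(O)CCC/C=C\C[C@@H]1CN(S(=O)(=O)c2cccc3ccccc23)C[C@@H]1c1ccccc1O` — 6.31 nM
compound 2 `O=C(O)CC/C=C\C[C@@H]1CN(S(=O)(=O)c2cccc3ccccc23)C[C@@H]1c1ccccc1O` — 1.59 nM
compound 3 `O=C(O)CC/C=C\C[C@@H]1CN(Cc2ccccc2)C[C@@H]1c1ccccc1O` — 251 nM

All three share the core of compound 1 and are compared in a functional assay (Cavia porcellus) for antagonist activity at thromboxane A2 receptor (Homo sapiens); a higher number here means weaker binding, a lower number tighter binding. Compound 3 stands highest of the three numbers; the nearest is compound 1, and the furthest is compound 2, both beyond the scatter. Among the compounds with values here, the only single-point step in the set, a 4.0-fold lower number from compound 1 to compound 2 (0.60 log units; beyond the scatter), concerns the chain that carries the acid and not the ring nitrogen, so it bears on the present change only indirectly. Compound 2 and compound 3 carry the same chain and differ at the nitrogen; their values show that the naphthylsulfonyl compound 2 gives 1.59 nM while the benzyl compound 3 gives 251 nM.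

Compound 4 `O=C(O)CC/C=C\C[C@@H]1CN(S(=O)(=O)c2ccc(Cl)cc2)C[C@@H]1c1ccccc1O` differs from compound 3 by (4-chlorophenyl)sulfonyl in place of benzyl on an amine nitrogen in a ring. Since compound 4 again carries an arylsulfonyl group on the ring nitrogen, as compound 2 does, a large downward step is expected, estimated at a 50-fold lower number from compound 3 to compound 4 (1.70 log units; beyond the scatter). Within the data shown here, the expected value for compound 4 in this assay is 5 nM, with a range from 1 nM to 30 nM; the uncertainty is wide because no measured compound carries this particular aryl group.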

Compound 4, dissociation constant: 1 nM
Beside the measured number, compound 4's estimate is 5.0-fold (0.70 log units) above it; measured number inside the range.
By their numbers in this assay, from the lowest: compounds 4 and 2 (each within the scatter of the next); then compound 1; then compound 3.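

The ring nitrogen now has a second arylsulfonyl example: in this assay the change from benzyl to (4-chlorophenyl)sulfonyl gives a 250-fold lower number from compound 3 to compound 4 (2.40 log units; beyond the scatter) and is the first directly listed step at this position, so the large gap seen with the naphthylsulfonyl compound 2 is not confined to that one aryl group. The aryl group on the sulfonyl sulfur can also differ with no separable effect, since 4-chlorophenyl in place of naphthalen-1-yl gives a 1.6-fold lower number from compound 2 to compound 4 (0.20 log units; within the scatter) and a monocyclic chlorinated ring serves as well here as the larger naphthalen-1-yl group. No measurement on hand accounts for the size of the step at the nitrogen.

The step from benzyl changes both the link to the nitrogen and the aryl group, so a 4-chlorobenzyl group, a benzoyl amide or a small methylsulfonyl group on the ring nitrogen would be needed to tell which part carries it. From the compounds shown here alone, the shorter acid chain is the only one seen with (4-chlorophenyl)sulfonyl, so it remains open whether the longer chain of compound 1 would shift this compound as it does the naphthylsulfonyl pair.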